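A few compounds are considered here, and "the series" means these few. Any claim that something is new, unique, unknown or untested is made for them only; others in the source may bear on it.

Measured so far:
- Compound 1 `COC(CC(=O)O)c1ccc(OCc2cccc(-c3c(C)cccc3C)c2)s1`: 210 nM
- Compound 2 `Cc1cccc(C)c1-c1cccc(OCc2ccc(CCC(=O)O)s2)c1`: 2420 nM

In a functional assay on cells for agonist activity at Free fatty acid receptor 1 (Homo sapiens), read by calcium flux (a lower number here means that less compound is needed, a higher number that more compound is needed for the effect), compound 1 gives the lower of the two numbers; compound 2 gives 2420 nM, a difference beyond the usual scatter. Compound 3 `Cc1cccc(C)c1-c1cccc(COc2ccc(CCC(=O)O)s2)c1` is compound 1 changed in one place: hydrogen in place of methoxy on a saturated chain carbon bound to an aromatic carbon and a saturated chain carbon. Within the data shown here, with no measured pair showing this change, the step from compound 1 to compound 3 in this assay is expected to raise the number moderately, beyond the scatter, by about a 3.8-fold higher number from compound 1 to compound 3 (0.58 log units; beyond the scatter). Compound 3 is therefore estimated at 800 nM, within a range of 250 nM to 2500 nM.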

Compound 3, half-maximal effective concentration: 32 nM
Compound 3: the middle estimate sits 25-fold (1.40 log units) above what was measured, and the stated range ends above it.
By their numbers in this assay, from the lowest: compound 3; then compound 1; then compound 2.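

In this assay, hydrogen in place of methoxy on this saturated chain carbon gives a 6.6-fold lower number from compound 1 to compound 3 (0.82 log units; beyond the scatter) and so shows that the 2-carboxyethyl chain needs no methoxy here to reach a low number. At this position, the methoxy group costs potency rather than adding to it. Nothing measured here explains the step. Only methoxy and hydrogen are shown on this carbon. On these data alone, whether a methyl or hydroxyl group in the same place would give a number nearer that of compound 3 or that of compound 1 stays open.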